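Swapping a phenyl for a carboxylic acid tail

The source may report more compounds than this note shows. Statements on the series, on what has been measured and on what is new or still open speak of the compounds shown alone.

Two sulfated sugar derivatives have been measured in an assay on isolated protein for binding affinity to fibroblast growth factor 2 (Homo sapiens), read by surface plasmon resonance; on this read-out lower numbers stand for tighter binding and higher numbers for weaker binding. Compound 1, `CO[C@H]1O[C@H](CNC(=O)CN(C(C)=O)C2CCCCCC2)[C@@H](OS(=O)(=O)O)[C@H](OS(=O)(=O)O)[C@@H]1OS(=O)(=O)O`, gives 410000 nM. Compound 2, `CCN(CC(=O)NC[C@H]1O[C@H](OC)[C@@H](OS(=O)(=O)O)[C@@H](OS(=O)(=O)O)[C@@H]1OS(=O)(=O)O)C(=O)CCCc1ccccc1`, gives 400000 nM, a number that sits beside that of compound 1, inside the usual scatter, so the two cannot be told apart on this read-out.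

Compound 3, `CCN(CC(=O)NC[C@H]1O[C@H](OC)[C@@H](OS(=O)(=O)O)[C@@H](OS(=O)(=O)O)[C@@H]1OS(=O)(=O)O)C(=O)CCCCC(=O)O`, has not yet been measured. It is built from compound 2 by a single change: carboxymethyl in place of phenyl on a saturated chain carbon, three bonds along the chain from a carbonyl carbon. Within the data shown here, no measured pair in this set shows what such a change does, so there is no step to lean on. The expectation for compound 3 is therefore a number close to that of compound 2, with a step of a 1.3-fold higher number from compound 2 to compound 3 (0.10 log units; within the scatter), which is not beyond the scatter. Compound 3 is estimated at 500000 nM in this assay, with a range from 150000 nM to 1500000 nM.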

Compound 3, dissociation constant: 480000 nM
The estimate for compound 3 lay 1.0-fold (0.02 log units) above the measured number, and the stated range covers the measured number.
By their numbers in this assay, from the lowest: compounds 2, 1 and 3 (each within the scatter of the next).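

Carboxymethyl in place of phenyl on a saturated chain carbon, three bonds along the chain from a carbonyl carbon, gives in this assay a 1.2-fold higher number from compound 2 to compound 3 (0.08 log units; within the scatter) and so leaves compound 2 and compound 3 indistinguishable. At this position, then, an aromatic ring and a carboxylic acid tail read alike, which compounds 1 and 2 alone could not show. The larger swap, ((4-carboxybutyl)carbonyl)(ethyl)amino in place of acetyl(cycloheptyl)amino on a saturated chain carbon bound to a carbonyl carbon, gives a 1.2-fold higher number from compound 1 to compound 3 (0.07 log units; within the scatter) and also stays inside the scatter. No supporting data bear on why these groups read alike.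

The compounds shown leave open whether an amine at the end of this tail would give a number beyond the scatter. The same question stands for a longer chain ending in the carboxylic acid.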